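Chlorophenyl for Benzyl on a Purine-Linked Benzamide

This account rests on a few compounds, and the source may have more. Where it says the series, first, only, none or still open, it means among the compounds named here.

The series is followed in a functional assay on NCI-H460 cells (Homo sapiens) for antiproliferative activity, read by CCK-8 assay, with a stated time of 72 h, tested at 8 uM; a lower number here means a weaker effect, a higher number a stronger effect of the compound at the concentration tested. Compound 3 `Nc1ccccc1NC(=O)c1ccc(Cn2cnc3c(NCc4ccccc4)nc(Cl)nc32)cc1` gives 61.2%, the highest of the three numbers recorded so far. Compound 1 `CCCCn1cnc2c(Nc3cccc(Cl)c3)nc(NCOCc3ccc(/C=C/C(=O)Nc4ccccc4N)cc3)nc21` gives 51.1%, which is lower by a margin beyond the scatter, and compound 2 `Nc1ccccc1NC(=O)/C=C/c1ccc(Cn2cnc3c(Nc4cccc(Cl)c4)nc(Cl)nc32)cc1` gives 29.4%, the lowest of the set. For the measured compounds named here, no two of these measured compounds differ in only one place, so no single step has been isolated.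

Compound 4 `Nc1ccccc1NC(=O)c1ccc(Cn2cnc3c(Nc4cccc(Cl)c4)nc(Cl)nc32)cc1` has not yet been measured. Relative to compound 3 it differs by one change: 3-chlorophenyl in place of benzyl on a nitrogen on an aromatic ring. Going by the values given here, no measured pair shows this change on its own, and the two compounds that already carry the (3-chlorophenyl)amino group, compound 1 and compound 2, also differ from compound 3 elsewhere, so their values cannot be read as a test of this change. For compound 4 a moderate downward step a number 11.2 percentage points lower from compound 3 to compound 4 (beyond the scatter) is expected, with the direction uncertain. The estimate for compound 4 is 50%, within 30% to 70%.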

Compound 4, a percentage reported as inhibition, at one concentration (the size of the read-out at that concentration, not a potency): 67%
The estimate for compound 4 lay 17 percentage points below the measured number; the measured number falls inside the stated range.
By their numbers in this assay, from the lowest: compound 2; then compound 1; then compounds 3 and 4 (each within the scatter of the next).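

In this assay, exchanging benzyl for 3-chlorophenyl on this nitrogen gives a number 5.8 percentage points higher from compound 3 to compound 4 (within the scatter), so the two groups cannot be told apart at this position. For the compounds shown here, the first single change with a clear effect lies elsewhere: (2-aminophenyl)carbamoyl in place of 2-((2-aminophenyl)carbamoyl)ethenyl on an aromatic carbon gives a number 37.6 percentage points higher from compound 2 to compound 4 (beyond the scatter). No information is available that explains the size of either step.

As far as these compounds go, it remains open whether the same exchange on the aromatic carbon would have a similar effect in compounds that carry benzylamino rather than (3-chlorophenyl)amino. From the compounds shown here alone, it is also open how far the nitrogen tolerates other groups, such as a cyclohexyl group or a longer alkyl chain, as the two groups compared here both contain a six-membered aromatic ring.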